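From compound 3 to compound 4: an expected solubility drop

The compounds below may be only part of what the source reports. "The series", "measured", "known", "first", "only" and "open" are said of these compounds alone.

Of the compounds shown here, three with a shared core have been measured in a physicochemical assay for solubility, read by HPLC, in phosphate buffer, at pH 6.5; on this read-out higher numbers stand for higher solubility and lower numbers for lower solubility. There, compound 1 `COC(=O)C1=C(CN2CCNCC2)NC(c2nccs2)=NC1(C)c1ccc(F)cc1` gives 250 ug/mL and compound 2 `COC(=O)C1=C(CN2CCCS2(=O)=O)NC(c2nccs2)=NC1(C)c1ccc(F)cc1` gives 125 ug/mL. Compound 3 `COC(=O)C1=C(CN(C)C2(C(=O)O)CC2)NC(c2nccs2)=NC1(C)c1ccc(F)cc1` reads > 510 ug/mL, and this is a limit of the assay, not a number.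

Compound 4 `COC(=O)C1=C(COC2CCOC2)NC(c2nccs2)=NC1(C)c1ccc(F)cc1` has not been measured. It carries (oxolan-3-yl)oxy, and its difference from compound 3 is a group of 6 heavy atoms (4 carbon, 2 oxygen; one five-membered non-aromatic ring with 1 hetero atom) in place of a group of 8 heavy atoms (5 carbon, 1 nitrogen, 2 oxygen; one three-membered non-aromatic ring of carbon only), on a saturated chain carbon bound to a double-bonded ring carbon. Neither the leaving group nor the entering group has a net charge.

Three measured steps changed the group at this same place. They are a 2.0-fold lower number from compound 1 to compound 2 (0.30 log units; within the scatter), then an at least 2.0-fold higher number from compound 1 to compound 3 (0.30 log units; that floor lies within the scatter), and finally an at least 4.0-fold higher number from compound 2 to compound 3 (0.61 log units; beyond the scatter). Only the last of these gives a firm size, and it is a floor rather than an exact step. Compound 4 loses the group of compound 3, the group that went with an at least 4.0-fold higher number from compound 2 to compound 3 (0.61 log units; beyond the scatter), so a lower number is expected. Going by the values given here, no measured compound carries the entering group, which leaves the size of the drop uncertain. The expected step is an at least 4.2-fold lower number from compound 3 to compound 4 (0.62 log units; beyond the scatter). For compound 4 the estimated value is 120 ug/mL, with an expected range from 40 ug/mL to 350 ug/mL.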

Compound 4, solubility: 30 ug/mL
Beside the measured number, compound 4's estimate is 4.0-fold (0.60 log units) above it; measured number below the stated range.
By their numbers in this assay, from the lowest: compound 4; then compounds 2 and 1 (each within the scatter of the next). At a limit, above all of these: compound 3.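

In this assay, this place on the saturated chain carbon can now push the number down as well as up, and the fall is clear of the scatter from both earlier compounds with a firm reading: a 4.2-fold lower number from compound 2 to compound 4 (0.62 log units; beyond the scatter), and an 8.3-fold lower number from compound 1 to compound 4 (0.92 log units; beyond the scatter). The widest gap shown at this place is an at least 17-fold lower number from compound 3 to compound 4 (1.23 log units; beyond the scatter), although (oxolan-3-yl)oxy differs from the group it replaces by only a small count of heavy atoms. Compound 3 reads as a limit and not as a number, so that last step gives only a floor: the limit of > 510 ug/mL in this assay, at which 1 of the 4 values shown sits.

Among these four compounds, (oxolan-3-yl)oxy is the only group without nitrogen and gives the lowest reading, with no compound shown going against that, but four compounds cannot tell whether the nitrogen is what matters or whether something else about the groups does. A morpholine, which holds a ring nitrogen and a ring oxygen together, and a simple amine or a carboxylic acid on a longer chain would help separate these possibilities.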